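The compounds below may be only part of what the source reports. "The series", "measured", "known", "first", "only" and "open" are said of these compounds alone.

In a functional assay on HepG2 cells (Homo sapiens) for cytotoxicity, read by MTT assay, with a stated time of 72 h (on this read-out higher numbers stand for weaker inhibition and lower numbers for stronger inhibition), compound 3 (`CC1CCN(c2ccc(Nc3ncc4nc(Nc5ccccc5)n(C5CCCC5)c4n3)cc2)CC1`) stands at > 5000 nM as a limit and not a number. Compound 1 (`CN1CCN(c2ccc(Nc3ncc4nc(Nc5ccccc5)n(C5CCCCC5)c4n3)cc2)CC1`) gives > 5000 nM as a limit too. Compound 2 (`Cc1cc(C)cc(-n2c(Nc3ccccc3)nc3cnc(Nc4ccc(N5CCN(C)CC5)cc4)nc32)c1`) gives > 5000 nM as a limit as well. Going by the values given here, the series so far thus shows the limit of > 5000 nM in this assay, at which 3 of the 3 values shown sit, and no readable number.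

The change to compound 4 (`c1ccc(Nc2ncc3nc(Nc4ccccc4)n(C4CCCC4)c3n2)cc1`) is hydrogen in place of 4-methylpiperidin-1-yl on an aromatic carbon and amounts to hydrogen in place of 4-methylpiperidin-1-yl on an aromatic carbon. Among the compounds with values here, the only measured step is a step that the two limits leave unreadable from compound 1 to compound 2 and it is 3,5-dimethylphenyl in place of cyclohexyl on an aromatic nitrogen, so it concerns another place and offers no size to carry over. Within the data shown here, no measured step touches the group that leaves here. No direction can be read from these data, and no step beyond the scatter is expected. That expectation leans on compound 3 at > 5000 nM as a limit and on nothing finer.

The step expected is a step that the limit leaves unreadable from compound 3 to compound 4 as a rough estimate only. For compound 4 the expected value is 6000 nM with an estimated range from 2500 nM to 15000 nM and a good chance of only a limit.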

Compound 4, half-maximal inhibitory concentration: > 5000 nM
Compound 4: a limit, no number; the forecaster's own chance of this, stated with the estimate: 85%; the middle value is on the limit's open side.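

Compound 3 and compound 4 both end in a limit and not a number in this assay, so no step can be read between them. The compounds shown leave open whether hydrogen or 4-methylpiperidin-1-yl at this place makes any difference in this assay, and how far each compound lies from the limit: the limit of > 5000 nM in this assay, at which 4 of the 4 values shown sit.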